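A few compounds are considered here, and "the series" means these few. Any claim that something is new, unique, unknown or untested is made for them only; others in the source may bear on it.

Of the compounds shown here, three built on one shared core have been tested in a functional assay on MCF7 cells (Homo sapiens) for cytotoxicity, read by MTT assay, with a stated time of 24 h, tested at 1.6 ug/mL; on this read-out higher numbers stand for a stronger effect at the one concentration tested and lower numbers for a weaker effect. Compound 1 `Cn1nnnc1SCC(=O)Nc1ccc(-c2nc(-c3ccccc3)c(-c3ccccc3)n2C)cc1` gives 34.3% in this assay. Compound 2 `Cc1nnc(SCC(=O)Nc2ccc(-c3nc(-c4ccccc4)c(-c4ccccc4)n3C)cc2)s1` gives 37.5%. Compound 3 `CN1CCN(CC(=O)Nc2ccc(-c3nc(-c4ccccc4)c(-c4ccccc4)n3C)cc2)CC1` gives 2.9%, the lowest of the three numbers. The step of a number 3.2 percentage points higher from compound 1 to compound 2 (within the scatter) lies within the scatter, whereas a number 31.4 percentage points lower from compound 1 to compound 3 (beyond the scatter) and a number 34.6 percentage points lower from compound 2 to compound 3 (beyond the scatter) are both beyond it, so compound 3 stands clearly below the other two and is the weakest of the set.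

Compound 4 `Cn1c(-c2ccc(NC(=O)CN3CCN(c4ccccc4)CC3)cc2)nc(-c2ccccc2)c1-c1ccccc1` has not yet been measured in this assay. It differs from compound 3 by phenyl in place of methyl on an amine nitrogen in a ring; cut one bond further out, 4-methylpiperazin-1-yl becomes 4-phenylpiperazin-1-yl. Within the data shown here, none of the measured steps alters a group on the ring nitrogen of this six-membered non-aromatic ring. The two steps that reach compound 3, a number 31.4 percentage points lower from compound 1 to compound 3 (beyond the scatter) and a number 34.6 percentage points lower from compound 2 to compound 3 (beyond the scatter), replace the whole (1-methyl-1H-tetrazol-5-yl)sulfanyl or (5-methyl-1,3,4-thiadiazol-2-yl)sulfanyl with the amine ring, so they place compound 3 at the bottom but say nothing about a phenyl on that ring nitrogen. With so little to go on, the step of a number 7.1 percentage points higher from compound 3 to compound 4 (within the scatter) is expected to be small, quite possibly not beyond the scatter. Compound 4 is therefore estimated at 10%, with a likely range from 0% to 30%.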

Compound 4, a percentage reported as activity, at one concentration (the size of the read-out at that concentration, not a potency): 21.3%
Compound 4: middle estimate off by 11.3 percentage points, on the low side; low and high end bracket the measured number.
By their numbers in this assay, from the lowest: compound 3; then compound 4; then compounds 1 and 2 (each within the scatter of the next).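

In this assay, among these compounds, the step of a number 18.4 percentage points higher from compound 3 to compound 4 (beyond the scatter) shows that the group on the amine nitrogen in the ring affects the read-out, something the earlier steps could not show as they exchanged the whole group on the saturated chain carbon. The low number of compound 3 therefore does not hold for every compound with this six-membered ring: 4-phenylpiperazin-1-yl recovers part of the gap, yet the steps of a number 16.2 percentage points lower from compound 2 to compound 4 (beyond the scatter) and a number 13 percentage points lower from compound 1 to compound 4 (beyond the scatter) still leave compound 4 short of the two compounds with a sulfur-linked ring. No measurement is at hand that would explain this change.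

The compounds shown leave open whether the rise depends on the aromatic ring itself or would also appear with a non-aromatic carbon group on that nitrogen, such as an ethyl, a cyclohexyl or a benzyl. On these data alone, it is also open whether a substituted phenyl, such as a 4-chlorophenyl or a 4-methoxyphenyl, would bring the number closer to those of compound 1 and compound 2.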